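This account rests on a few compounds, and the source may have more. Where it says the series, first, only, none or still open, it means among the compounds named here.

Measured compounds:
Compound 1 `COC(=O)c1ccc(CCCCCCC(=O)c2ncc(-c3ccccn3)o2)cc1`
Compound 2 `O=C(CCCCCCc1ccccn1)c1ncc(-c2ccccn2)o1`
Compound 3 `O=C(CCCCCCc1ccccc1Cl)c1ncc(-c2ccccn2)o1`

In an assay for inhibition of Fatty-acid amide hydrolase 1 (Rattus norvegicus) (a lower number here means a stronger inhibitor, a higher number a weaker inhibitor), compound 1 gives 1.5 nM. Compound 2 gives 120 nM. Compound 3 gives 1.9 nM, the second highest of the three numbers; compound 1 lies within the scatter of it, while compound 2 stands far higher. Compound 4 `COc1ccc(CCCCCCC(=O)c2ncc(-c3ccccn3)o2)cc1` differs from compound 3 by 4-methoxyphenyl in place of 2-chlorophenyl on a saturated chain carbon, six bonds along the chain from a carbonyl carbon. Among the compounds with values here, the one step measured at this chain position, a 63-fold lower number from compound 2 to compound 3 (1.80 log units; beyond the scatter), was large, but it exchanged a pyridine ring for a benzene ring; no measured step swaps one substituted benzene ring for another. Compound 1, which also ends in a substituted benzene ring, sits within the scatter of compound 3, which suggests such swaps matter little here. Compound 4 is therefore expected to give about 2.5 nM, between 1 nM and 8 nM. That estimated change, a 1.3-fold higher number from compound 3 to compound 4 (0.12 log units; within the scatter), is expected to stay within the scatter.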

Compound 4, inhibition constant: 6.2 nM
The estimate for compound 4 lay 2.5-fold (0.39 log units) below the measured number, and the stated range covers the measured number.
By their numbers in this assay, from the lowest: compounds 1 and 3 (each within the scatter of the next); then compound 4; then compound 2.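

In this assay, the choice of substituted benzene ring at this chain position does matter: a 3.3-fold higher number from compound 3 to compound 4 (0.51 log units; beyond the scatter) and, with methoxy in place of methoxycarbonyl, a 4.1-fold higher number from compound 1 to compound 4 (0.62 log units; beyond the scatter). Both shifts are far smaller than a 19-fold lower number from compound 2 to compound 4 (1.29 log units; beyond the scatter), which shows that 4-methoxyphenyl, like 2-chlorophenyl, gives a much lower number than pyridin-2-yl. Nothing available explains these differences. As far as these compounds go, whether 2-methoxyphenyl would track 2-chlorophenyl or 4-methoxyphenyl remains open, and so does how a carboxylic acid in place of methoxy would compare.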